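Chain Lengthening and Cytotoxicity Limits in Two Related Cores

The compounds below may be only part of what the source reports. "The series", "measured", "known", "first", "only" and "open" are said of these compounds alone.

Compound 1 `CCCCCCC#Cc1cc2cn(COCCO)c(=O)nc2o1` and compound 2 `CCCCCCCC#Cc1cc2cn(COCCO)c(=O)nc2o1` share one core; compound 3 `CCCCCc1cc2cn(COCCO)c(O)nc-2n1` and compound 4 `CCCCCCc1cc2cn(COCCO)c(O)nc-2n1` share another, and the difference between the two cores is not broken down here. In a functional assay on HEL cells (Homo sapiens) (on this read-out lower numbers stand for higher toxicity in this test and higher numbers for lower toxicity in this test), compound 1 gives > 50000 nM, a limit of the assay rather than a number. Compound 2 likewise reaches only the limit > 50000 nM in this assay. The change between them, (methyl in place of hydrogen on a saturated chain carbon, six bonds along the chain from a triple-bonded carbon), reads as a step that the two limits leave unreadable from compound 1 to compound 2; both values sit at the limit of > 50000 nM in this assay, at which 2 of the 3 values shown sit. Compound 3 in this assay also stops at a limit, > 200000 nM, which is the limit of > 200000 nM in this assay, at which 1 of the 3 values shown sits. For the measured compounds named here, compound 4 arises from compound 3 by methyl in place of hydrogen on a saturated chain carbon, five bonds along the chain from an aromatic carbon, the same kind of change as the one from compound 1 to compound 2, although the place differs: five bonds along the chain from an aromatic carbon rather than six bonds along the chain from a triple-bonded carbon. For compound 4 no more than a limit is expected in this assay, so the step that the limit leaves unreadable from compound 3 to compound 4 is an estimate that rests on compound 3 standing at the limit of > 200000 nM in this assay, at which 1 of the 3 values shown sits, while compound 1 and compound 2 both stand at the limit of > 50000 nM in this assay, at which 2 of the 3 values shown sit. Compound 4 is expected to read about 250000 nM, between 100000 nM and 1000000 nM.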

Compound 4, half-maximal cytotoxic concentration: > 200000 nM
Compound 4: a limit, no number (the forecaster's own chance of this, stated with the estimate: 85%); the middle value does not contradict the limit.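

In this assay compound 4 gives > 200000 nM, a limit of the assay and not a number. Compound 3 also stands at a limit, so no step from compound 3 to compound 4 can be read: the limit of > 200000 nM in this assay, at which 2 of the 4 values shown sit.

The compounds shown leave open whether adding methyl to the chain changes toxicity in this test in either core.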